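The source may report more compounds than this note shows. Statements on the series, on what has been measured and on what is new or still open speak of the compounds shown alone.

Measured compounds:
Compound 1, `CC(C)(C)c1cn(C[C@H](O)[C@H]2OC(=O)C(OCc3ccccc3)=C2OCc2ccccc2)nn1`, gives 34000 nM.
Compound 2, `O=C1O[C@H]([C@@H](O)Cn2cc(-c3cc(F)cc(F)c3)nn2)C(OCc2ccccc2)=C1OCc1ccccc1`, gives 41200 nM.
Compound 3, `Cc1ccc(-c2cn(C/C=C3\OC(=O)C(OCc4ccccc4)=C3OCc3ccccc3)nn2)cc1`, reaches only the limit of > 100000 nM, and no number is known for it.

Among the two numbers in a functional assay on A549 cells (Homo sapiens) for antiproliferative activity, read by MTT assay, with a stated time of 72 h (on this read-out lower numbers stand for stronger inhibition and higher numbers for weaker inhibition), compound 2 carries the higher one; the nearest is compound 1, and the step of a 1.2-fold higher number from compound 1 to compound 2 (0.08 log units; within the scatter) lies within the scatter, so the two cannot be ordered. Compound 3 sits at the limit described in the limit of > 100000 nM in this assay, at which 1 of the 3 values shown sits.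

Compound 4, `O=C1O[C@H]([C@@H](O)Cn2cc(CNS(=O)(=O)c3ccc(F)cc3)nn2)C(OCc2ccccc2)=C1OCc1ccccc1`, differs from compound 2 in one place: (((4-fluorophenyl)sulfonyl)amino)methyl in place of 3,5-difluorophenyl on an aromatic carbon. Among the measured compounds shown here, the only measured step that touches the same aromatic carbon is the one from compound 1 to compound 2, and it stayed within the scatter. For the measured compounds named here, no measured step replaces an aryl group there with a (((4-fluorophenyl)sulfonyl)amino)methyl group, so no direction can be drawn from the data. Compound 4 is therefore expected to give 40000 nM in this assay, within 14000 nM to 100000 nM, which means an expected step of a 1.0-fold lower number from compound 2 to compound 4 (0.01 log units; within the scatter) of no clear size beyond the scatter.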

Compound 4, half-maximal inhibitory concentration: 22500 nM
Compound 4: the middle estimate sits 1.8-fold (0.25 log units) above what was measured; measured number inside the range.
By their numbers in this assay, from the lowest: compounds 4, 1 and 2 (each within the scatter of the next). At a limit, above all of these: compound 3.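

In this assay, putting (((4-fluorophenyl)sulfonyl)amino)methyl on this aromatic carbon gives a 1.8-fold lower number from compound 2 to compound 4 (0.26 log units; within the scatter) and a 1.5-fold lower number from compound 1 to compound 4 (0.18 log units; within the scatter), so compounds 1, 2 and 4 cannot be ordered. Until now this carbon had carried only tert-butyl and 3,5-difluorophenyl; it now also carries a larger group with a hydrogen-bond donor and hydrogen-bond acceptors, and neither step leaves the scatter. Nothing shown here gives a cause for these numbers.

The compounds shown leave open whether an amine, a carboxylic acid or a longer alkyl chain on this carbon would move the number beyond the scatter. They also leave open whether free hydroxyl groups in place of the two benzyl ethers on the shared core would do so.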